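The source may report more compounds than this note shows. Statements on the series, on what has been measured and on what is new or still open speak of the compounds shown alone.

Measured so far in a physicochemical assay for solubility, read by HPLC, using the shake flask method, in phosphate buffer, with a stated time of 20 h, at pH 6.5; on this read-out higher numbers stand for higher solubility and lower numbers for lower solubility:
Compound 1 `CN1CCN(CC2CCN(c3nccc4[nH]c(-c5cccc(OC(F)(F)F)c5)nc34)CC2)CC1` gives 200000 nM
Compound 2 `CN1CCN(CC2CCN(c3nccc4[nH]c(-c5ccc(F)c(Cl)c5)nc34)CC2)CC1` gives 155000 nM
Compound 3 `CN1CCN(CC2CCN(c3nccc4[nH]c(-c5ccc(F)c(C(F)(F)F)c5)nc34)CC2)CC1` gives 165000 nM

Compound 3 cannot be separated from the other two: the steps that reach it are a 1.2-fold lower number from compound 1 to compound 3 (0.08 log units; within the scatter) and a 1.1-fold higher number from compound 2 to compound 3 (0.03 log units; within the scatter) and neither gives it a distinct place among the three numbers.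

Compound 4 `CN1CCN(CC2CCN(c3nccc4[nH]c(-c5cccc(OCCN)c5)nc34)CC2)CC1` keeps everything in compound 3 except one group. It has 3-(2-aminoethoxy)phenyl in place of 4-fluoro-3-(trifluoromethyl)phenyl on an aromatic carbon of a five-membered aromatic ring with 2 nitrogen, between two ring nitrogen atoms 3-(2-aminoethoxy)phenyl in place of 4-fluoro-3-(trifluoromethyl)phenyl on an aromatic carbon and this is the same place that varies across the measured compounds.

Among the measured compounds shown here, the steps that bear on it are therefore a 1.3-fold lower number from compound 1 to compound 2 (0.11 log units; within the scatter) and the two already given, and all three stay small. None of them, however, involves a group like 3-(2-aminoethoxy)phenyl, so they are only a weak guide here. The step expected is a 1.3-fold higher number from compound 3 to compound 4 (0.12 log units; within the scatter) and so no change beyond the scatter is anticipated, although the estimated range is kept wide for this unprecedented group. For compound 4 the estimated value is 220000 nM with an expected range from 130000 nM to 450000 nM in this measurement.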

Compound 4, solubility: 200000 nM
Estimate against measurement, compound 4: 1.1-fold (0.04 log units) above; the measured number falls inside the stated range.
By their numbers in this assay, from the lowest: compounds 2, 3, 1 and 4 (each within the scatter of the next).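

In this assay, among the compounds shown here, the aromatic carbon between two ring nitrogen atoms had so far carried only phenyl groups bearing chloro, fluoro, trifluoromethyl or trifluoromethoxy, and compound 4 extends the series to a group that contains an amine. That group, 3-(2-aminoethoxy)phenyl, differs in kind from the three before it, yet the read-out gives a 1.2-fold higher number from compound 3 to compound 4 (0.08 log units; within the scatter) and a 1.3-fold higher number from compound 2 to compound 4 (0.11 log units; within the scatter) and also no change at the digits printed from compound 1 to compound 4 (within the scatter) where 2-aminoethyl stands in place of trifluoromethyl on the same oxygen, so all four compounds remain inseparable even with this much larger change of group at this position. Nothing at hand accounts for this flat read-out.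

The compounds shown leave open whether the read-out would stay as flat with a carboxylic acid at the end of the chain, a longer chain on the oxygen, or a plain methoxy with no amine at all. They also leave open whether the same holds for the aminoethoxy group on a core lacking the methylpiperazine side chain that all four compounds share.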